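The source may hold more compounds than are shown below. What is called first, only, known or untested is meant among the compounds shown, and "the series" means these compounds.

Measured in a functional assay on OVCAR-3 cells (Homo sapiens) for antiproliferative activity, read by MTT assay, with a stated time of 24 h; a lower number here means a stronger inhibitor, a higher number a weaker inhibitor:
- compound 1 `Cc1ccccc1NNC(=O)c1cccc(NS(=O)(=O)c2cnc(O)nc2O)c1`: > 20000 nM, a limit
- compound 2 `O=C(NNc1ccccc1Cl)c1cccc(NS(=O)(=O)c2cnc(O)nc2O)c1`: 3350 nM
- compound 3 `O=C(NNc1ccc(F)cc1)c1cccc(NS(=O)(=O)c2cnc(O)nc2O)c1`: > 20000 nM, a limit

Compound 3 has no number, only a limit of > 20000 nM. This is the limit of > 20000 nM in this assay, at which 2 of the 3 values shown sit.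

Compound 4 `Cc1ccc(C(=O)NNC(=O)c2cccc(NS(=O)(=O)c3cnc(O)nc3O)c2)cc1` carries a change on the amine nitrogen whose other neighbour is the amide-type nitrogen: (4-methylphenyl)carbonyl in place of 4-fluorophenyl on an amine nitrogen. In words, (4-methylphenyl)carbonyl stands in place of 4-fluorophenyl.

Two measured steps change the group at this place: an at least 5.9-fold higher number from compound 2 to compound 3 (0.77 log units; beyond the scatter), and a step that the two limits leave unreadable from compound 1 to compound 3. The first shows that this group can matter in this assay, while the second has no readable size. Neither step introduces a carbonyl there, so neither gives a size for this change. Among the measured compounds shown here, compound 2, at 3350 nM, is the only compound with a number, and it marks the favourable edge of what is expected.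

No step beyond the scatter is therefore expected, and another limit reading is quite likely. The expected change is an at least 1.1-fold lower number from compound 3 to compound 4 (0.04 log units; that floor lies within the scatter). For compound 4 the estimated value is 18000 nM, with an expected range of 5000 nM to 40000 nM.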

Compound 4, half-maximal inhibitory concentration: > 20000 nM
Compound 4 gave a limit, no number; the forecaster's own chance of this, stated with the estimate: 60%; middle value at least 1.1-fold (0.04 log units) away from the limit.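

In this assay, among the compounds shown here, (4-methylphenyl)carbonyl in place of 2-chlorophenyl on the amine nitrogen gives an at least 5.9-fold higher number from compound 2 to compound 4 (0.77 log units; beyond the scatter), so the one reading with a number is not kept once a carbonyl stands at this place. The steps from compound 1 and from compound 3 to compound 4 cannot be read, as both ends of each are limits. Compound 2 therefore remains the only compound with a number, and a carbonyl-bearing group now joins the 2-methylphenyl and 4-fluorophenyl groups at the same ceiling: the limit of > 20000 nM in this assay, at which 3 of the 4 values shown sit.

From the compounds shown here alone, how far compound 1, compound 3 and compound 4 lie apart stays open. Also open, going by these compounds, is whether a 2-bromophenyl group or a (2-chlorophenyl)carbonyl group on this amine nitrogen would give a number in this assay.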